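The source may report more compounds than this note shows. Statements on the series, on what has been measured and on what is new or still open speak of the compounds shown alone.

Working notes on the series.

Of the compounds shown here, two carry numbers so far. Compound 1 `CCCc1ccc(NC(=O)N[C@H](C)c2ccccc2)cc1` gives 33% in an ADME assay on the whole organism with Oryza sativa as the target, tested at 0.1 uM; on this read-out lower numbers stand for a stronger effect and higher numbers for a weaker effect at the one concentration tested. Compound 2 `C[C@@H](NC(=O)Nc1ccc(C(F)(F)F)cc1)c1ccccc1` gives 93% in this assay. Among the compounds with values here, the one step between them, a number 60 percentage points higher from compound 1 to compound 2 (beyond the scatter), came with trifluoromethyl in place of propyl on an aromatic carbon. On these two numbers compound 2 stands highest, and its nearest neighbour, compound 1, is separated from it by that step, beyond the scatter.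

The next compound, compound 3 `C[C@@H](NC(=O)Nc1ccc(I)cc1)c1ccccc1`, differs from compound 2 by iodo in place of trifluoromethyl on an aromatic carbon. Within the data shown here, no measured step involves an iodo group, so nothing bears on this change directly. Among the measured compounds shown here, the only step in hand, from compound 1 to compound 2, shows that exchanging the group at this place can move the read-out by a large amount in either direction, which argues for a wide range rather than a firm direction. A number lower than that of compound 2 is expected, but with broad uncertainty: compound 3 is estimated at 65%, with a range from 30% to 95%, a step of a number 28 percentage points lower from compound 2 to compound 3 (beyond the scatter).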

Compound 3, a percentage reported as activity, at one concentration (the size of the read-out at that concentration, not a potency): 100%
Compound 3: middle estimate off by 35 percentage points, on the low side, outside the stated range (above it).
By their numbers in this assay, from the lowest: compound 1; then compounds 2 and 3 (each within the scatter of the next).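

this assay gives a number 7 percentage points higher from compound 2 to compound 3 (within the scatter), so on this aromatic carbon, para to a large group, iodo with its single heavy atom and trifluoromethyl with its four cannot be told apart on this read-out. The second replacement of propyl gives a number 67 percentage points higher from compound 1 to compound 3 (beyond the scatter), a large step in the same direction as a number 60 percentage points higher from compound 1 to compound 2 (beyond the scatter), which makes compound 1 the one that stands apart among these three compounds, with no compound among them going against this, rather than the result of one particular replacement. Nothing available accounts for the separation of the propyl compound from the other two or for the closeness of the iodo and trifluoromethyl compounds.

From the compounds shown here alone, whether the low number belongs to propyl alone or extends to other carbon chains remains open, and ethyl or butyl at this place would bear on that. The compounds shown also leave open where an amine or a carboxylic acid at this place would fall relative to compound 1 and the pair of compound 2 and compound 3.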